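Extending a silicon-bound benzyl to phenethyl

The compounds below may be only part of what the source reports. "The series", "measured", "known", "first", "only" and "open" are said of these compounds alone.

Compound 2 `CCN(C/C=C/C#CC(C)(C)C)Cc1cccc(OC[Si](C)(C)Cc2ccccc2)c1`: 130 nM
Compound 1 `CCN(C/C=C/C#CC(C)(C)C)Cc1cccc(OC[Si](C)(C)c2ccc(C(N)=O)cc2)c1`: 5000 nM

Compound 2 gives the lowest number of the two measured in a functional assay on liver (Sus scrofa) for inhibition of squalene monooxygenase (Homo sapiens), using microsomes; a lower number here means a stronger inhibitor, a higher number a weaker inhibitor; compound 1 stands a long way behind, as the step of a 38-fold lower number from compound 1 to compound 2 (1.59 log units; beyond the scatter) shows. Compound 3 `CCN(C/C=C/C#CC(C)(C)C)Cc1cccc(OC[Si](C)(C)CCc2ccccc2)c1` differs from compound 2 by benzyl in place of phenyl on a saturated chain carbon bound to a silicon atom. Among the measured compounds shown here, the one measured step swapped a 4-carbamoylphenyl for a benzyl on the silicon, a different change, so nothing measured bears directly on this one. A step no larger than the scatter is expected, in either direction. For compound 3 the estimated value is 150 nM, between 50 nM and 500 nM, a step of a 1.2-fold higher number from compound 2 to compound 3 (0.06 log units; within the scatter).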

Compound 3, half-maximal inhibitory concentration: > 10000 nM
Compound 3: only a limit was reported; the forecaster's own chance of this, stated with the estimate: 3%; at least 66-fold (1.82 log units) between middle value and limit.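

Going from benzyl to phenethyl on the silicon is far from a neutral change: an at least 76-fold higher number from compound 2 to compound 3 (1.88 log units; beyond the scatter) in this assay. Compound 3 is reported only as a limit: the limit of > 10000 nM in this assay, at which 1 of the 3 values shown sits. The step of an at least 2.0-fold higher number from compound 1 to compound 3 (0.30 log units; that floor lies within the scatter) therefore does not separate these two compounds, so phenethyl can only be said to offer no clear gain over 4-carbamoylphenyl.

On these data alone, it remains open whether an unsubstituted phenyl directly on the silicon, or a benzyl carrying a fluorine on its ring, would match compound 2.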